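A Thioether Swap Between Two Equally Weak Growth Inhibitors

The source may hold more compounds than are shown below. What is called first, only, known or untested is meant among the compounds shown, and "the series" means these compounds.

Measured compounds:
- compound 1, `COc1ccc(C(=O)/C(=C\c2ccc(O)c([N+](=O)[O-])c2)SCc2ccc(Br)cc2)cc1`: 10000 nM
- compound 2, `O=C(/C(=C\c1ccc(O)c([N+](=O)[O-])c1)Sc1c(F)c(F)c(F)c(F)c1F)c1ccc(Br)cc1`: 10000 nM

Both compounds were tested in a functional assay on DU-145 cells (Homo sapiens) for inhibition, read by trypan blue exclusion, with a stated time of 96 h; on this read-out lower numbers stand for stronger inhibition of growth and higher numbers for weaker inhibition of growth. Compound 1 gives 10000 nM, and compound 2 gives 10000 nM. Compound 2 therefore stands level with compound 1 at the digits shown; the two readings fall within the scatter of each other, so no order between them can be claimed, and both sit at the weak end of what this assay records.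

The next compound, compound 3, `O=C(/C(=C\c1ccc(O)c([N+](=O)[O-])c1)SCc1ccc(Br)cc1)c1ccc(Br)cc1`, keeps the shared core of compound 2 and changes only the group on sulfur:

4-bromobenzyl in place of 2,3,4,5,6-pentafluorophenyl on a sulfur

Going by the values given here, no measured pair in this set isolates that change on its own. Among the compounds with values here, the only guide is that compound 1, which already carries a 4-bromobenzyl on sulfur, and compound 2, which carries a 2,3,4,5,6-pentafluorophenyl there, read the same in this assay. On that basis no step beyond the scatter is expected from compound 2 to compound 3, that is no change at the digits printed from compound 2 to compound 3 (within the scatter). Compound 3 is expected to give about 10000 nM, with a range from 4000 nM to 20000 nM.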

Compound 3, concentration for 50% growth inhibition: 10000 nM
The estimate for compound 3 equals the measured number at the digits printed, and the stated range covers the measured number.
By their numbers in this assay, from the lowest: compounds 1, 2 and 3 (each within the scatter of the next).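

Going by these compounds alone, compound 3 completes the first pair in this set that differs only in the group on sulfur: in this assay, 4-bromobenzyl in place of 2,3,4,5,6-pentafluorophenyl gives no change at the digits printed from compound 2 to compound 3 (within the scatter), even though a ring carrying fluorine is exchanged for a benzyl group carrying bromine. It also completes a pair that differs at the other end of the molecule, where bromo in place of methoxy on an aromatic carbon gives no change at the digits printed from compound 1 to compound 3 (within the scatter), so neither single change moves the reading in this assay. No supporting data bear on why these readings coincide.

All three compounds share one reading at the weak end of the assay, so these pairs do not show whether either position can affect growth inhibition when other groups are placed there. On these data alone, an amine or a carboxylic acid on the aromatic carbon, or a longer chain on sulfur, remains open, as does any change to the hydroxyl and nitro groups of the shared core.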